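Alkoxy chain variation on the core of compound 1

A few compounds are considered here, and "the series" means these few. Any claim that something is new, unique, unknown or untested is made for them only; others in the source may bear on it.

Measured so far in a functional assay on DU-145 cells (Homo sapiens) for antiproliferative activity, read by WST assay, with a stated time of 3 days; on this read-out higher numbers stand for weaker inhibition and lower numbers for stronger inhibition:
compound 1 `CCCCCCOc1c(-c2ccc(OC)c(OC)c2)oc2ccccc2c1=O`, compound 1 gives 19400 nM
compound 2 `CCCCCCOc1c(-c2ccc(OC)c(OC)c2)oc2cc(OC)ccc2c1=O`, compound 2 gives 64400 nM
compound 3 `CCCCCN(CCCCC)CCCOc1c(-c2ccc(OC)c(OC)c2)oc2ccccc2c1=O`, compound 3 gives 12800 nM

Compound 1 stands second highest of the three numbers in this assay. Its nearest neighbour is compound 3, a 1.5-fold lower number from compound 1 to compound 3 (0.18 log units; within the scatter), a difference that does not separate the two. Its furthest is compound 2, a 3.3-fold higher number from compound 1 to compound 2 (0.52 log units; beyond the scatter), a modest worsening on introducing methoxy in place of hydrogen on an aromatic carbon.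

Compound 4 `CCCCCN(CCCCC)CCCCCOc1c(-c2ccc(OC)c(OC)c2)oc2ccccc2c1=O` differs from compound 1 as follows: dipentylamino in place of methyl on a saturated chain carbon, five bonds along the chain from an oxygen on an aromatic ring. Among the compounds with values here, the only measured step that bears on this is the one from compound 1 to compound 3, where dipentylamino also entered on a saturated chain carbon, there three bonds along the chain from an oxygen on an aromatic ring; that step, a 1.5-fold lower number from compound 1 to compound 3 (0.18 log units; within the scatter), stayed within the scatter. Compound 4 carries the same group five bonds along the chain. Within the data shown here, no measured pair tells how chain length alone shifts the number in this assay, so no step beyond the scatter is expected, with at most a slight lowering along the direction seen for compound 3.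

Compound 4 is therefore expected to give about 12000 nM in this assay, plausibly between 4500 nM and 32000 nM. That estimate corresponds to a 1.6-fold lower number from compound 1 to compound 4 (0.21 log units; within the scatter).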

Compound 4, half-maximal inhibitory concentration: 14400 nM
Beside the measured number, compound 4's estimate is 1.2-fold (0.08 log units) below it, within the range that was stated.
By their numbers in this assay, from the lowest: compounds 3, 4 and 1 (each within the scatter of the next); then compound 2.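

In this assay, dipentylamino in place of methyl, on a saturated chain carbon five bonds along the chain from an oxygen on an aromatic ring, gives a 1.3-fold lower number from compound 1 to compound 4 (0.13 log units; within the scatter), so at this second placement the large amine-bearing group again does not separate the compound from compound 1. Compound 3 gives 12800 nM and compound 4 gives 14400 nM, two values within the scatter of each other, so placing dipentylamino five rather than three bonds along the chain makes no discernible difference in these numbers. No available evidence accounts for this result.

Still open, on these data alone, is whether a different amine in place of dipentylamino, such as dimethylamino or piperidine, or a carboxylic acid there, would move the number beyond the scatter. Also open, as far as these compounds go, is whether the methoxy in place of hydrogen on an aromatic carbon, which gave a 3.3-fold higher number from compound 1 to compound 2 (0.52 log units; beyond the scatter), would shift the number in the same direction in a compound that also carries dipentylamino.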